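The source may hold more compounds than are shown below. What is called first, only, known or untested is meant among the compounds shown, and "the series" means these compounds.

Of the compounds shown here, three built on one shared core have been measured in a functional assay on MCF7 cells (Homo sapiens) for cytotoxicity, read by sulforhodamine B assay, with a stated time of 24 h; a higher number here means a weaker inhibitor, a lower number a stronger inhibitor. Compound 1, `O=C1Nc2ccc(S(=O)(=O)N3CCOCC3)cc2/C1=N/c1ccc(O)cc1`, gives 52700 nM. Compound 2, `O=C1Nc2ccc(S(=O)(=O)N3CCOCC3)cc2/C1=N/c1cccc(C(F)(F)F)c1`, gives 41100 nM. Compound 3, `N/N=C1\C(=O)Nc2ccc(S(=O)(=O)N3CCOCC3)cc21`, gives 46800 nM. On these numbers compound 2 stands lowest, yet the gaps to compound 3 and to compound 1 both fall within the scatter, so none of the three can be set apart from the others.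

Compound 4 is `O=C1Nc2ccc(S(=O)(=O)N3CCOCC3)cc2/C1=N/NS(=O)(=O)c1ccccc1`. It differs from compound 2 in one place: (phenylsulfonyl)amino in place of 3-(trifluoromethyl)phenyl on a double-bonded nitrogen. The steps already measured all turn on what sits on that same double-bonded nitrogen. a 1.3-fold lower number from compound 1 to compound 2 (0.11 log units; within the scatter) and a 1.1-fold higher number from compound 2 to compound 3 (0.06 log units; within the scatter) show that exchanging one group for another there, whether an aryl group for another aryl group or an aryl group for amino, leaves the result within the scatter. With (phenylsulfonyl)amino now entering, the same kind of change is before us, and compound 4 is therefore expected to show no step beyond the scatter, namely a 1.1-fold higher number from compound 2 to compound 4 (0.04 log units; within the scatter). Compound 4 is estimated to give 45000 nM, within a range from 20000 nM to 100000 nM.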

Compound 4, half-maximal inhibitory concentration: 25300 nM
Compound 4: the middle estimate sits 1.8-fold (0.25 log units) above what was measured, within the range that was stated.
By their numbers in this assay, from the lowest: compounds 4, 2, 3 and 1 (each within the scatter of the next, the first and the last beyond it).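

In this assay the double-bonded nitrogen gives its first step beyond the scatter, a 2.1-fold lower number from compound 1 to compound 4 (0.32 log units; beyond the scatter) with (phenylsulfonyl)amino in place of 4-hydroxyphenyl, and this step is only modest. The two other changes stay within the scatter, a 1.6-fold lower number from compound 2 to compound 4 (0.21 log units; within the scatter) for the exchange with 3-(trifluoromethyl)phenyl and a 1.8-fold lower number from compound 3 to compound 4 (0.27 log units; within the scatter) for phenylsulfonyl in place of hydrogen on an amine nitrogen, so compound 4 separates from compound 1 alone. Nothing measured here explains that single separation.

The compounds shown leave open whether the sulfonyl link or the phenyl ring carries the step, which a methanesulfonylamino or a benzoylamino group on that nitrogen could tell. Also open, as far as these compounds go, is how in this assay a carboxylic acid or a longer chain on that phenyl ring would read.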